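The source may hold more compounds than are shown below. What is called first, only, known or untested is meant among the compounds shown, and "the series" means these compounds.

Measured compounds:
compound 1, `COc1ccc(C2N=C(SCc3ccccc3Cl)NC(C)=C2C(=O)Nc2ccc(F)cc2)cc1OC` — 39.2%
compound 2, `CC1=C(C(=O)Nc2ccc([N+](=O)[O-])cc2)C(c2ccc(Br)cc2)N=C(SCc2ccccc2)N1` — 37.6%

In a functional assay on the whole organism (artery, strain albino) with Rattus norvegicus as the target, with a stated time of 360 min, at a dose of 10 mg/kg by the oral route (on this read-out lower numbers stand for less inhibition and higher numbers for more inhibition at the one dose given (going by the name of the read-out)), compound 1 gives 39.2% and compound 2 gives 37.6%. The two numbers lie within the usual scatter of each other, so nothing can be said about which of the two is the stronger; on the numbers shown compound 2 stands as one of two compounds that read alike. Among the compounds with values here, no pair of measured compounds differs in one place only, so no step size has been established in this assay.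

Compound 3, `CC1=C(C(=O)Nc2ccc([N+](=O)[O-])cc2)C(c2ccc(Br)cc2)N=C(SCc2ccc(Cl)cc2)N1`, is not yet measured. It is derived from compound 2 by the change (chloro in place of hydrogen on an aromatic carbon), the new chloro sitting on an aromatic carbon of a six-membered aromatic ring of carbon only. The shared core and the amide-bearing and nitro-bearing parts of compound 2 are unchanged. Within the data shown here, with no measured step available, the step is expected to stay within the scatter, in either direction, and the estimated step from compound 2 to compound 3 is a number 2.4 percentage points higher from compound 2 to compound 3 (within the scatter). For compound 3 in this assay the estimate is 40%, with a range from 27% to 53%.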

Compound 3, a percentage reported as inhibition, in the whole organism at one dose (the size of the read-out at that dose, not a potency): 39.2%
The estimate for compound 3 lay 0.8 percentage points above the measured number; the measured number falls inside the stated range.
By their numbers in this assay, from the lowest: compounds 2, 1 and 3 (each within the scatter of the next).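

In this assay, within the data shown here, chloro in place of hydrogen on an aromatic carbon, para to a large group, gives a number 1.6 percentage points higher from compound 2 to compound 3 (within the scatter), the first step that can be read from a single-place difference. The position therefore carries the swap from benzylsulfanyl to (4-chlorobenzyl)sulfanyl, with the core and the amide-bearing, nitro-bearing and bromo-bearing parts unchanged, without the read-out separating the two compounds at this one oral dose. Nothing measured bears on the reason for this result.

The series still leaves open whether a group other than chloro at this same place, such as methoxy, an amine or a carboxylic acid, would give a step beyond the scatter, and whether a longer chain between the sulfur and the ring would do so. Steps from compound 1 to compound 2 or compound 3 cannot be read, since compound 1 differs from both in more than one place, so this single step says nothing yet about the other parts of the molecule.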